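Amide variation within the shared core

The source may hold more compounds than are shown below. What is called first, only, known or untested is meant among the compounds shown, and "the series" means these compounds.

Compound 2 `CCCNC(=O)CC1CCc2cc(OC)c(OC)cc21` gives 26.7% in a functional assay on the whole organism (strain Wistar) for inhibition, with Rattus norvegicus as the target, read by paw edema, with stated times of 60 min and 24 h, at a dose of 100 mg/kg by the oral route (on this read-out higher numbers stand for more inhibition at the one dose given (going by the name of the read-out) and lower numbers for less inhibition), the lowest of the three numbers measured. Compound 1 `CNC(=O)CC1CCc2cc(OC)c(OC)cc21` gives 33.3% in this assay; the gap a number 6.6 percentage points lower from compound 1 to compound 2 (within the scatter) stays within the scatter. Compound 3 `COc1cc2c(cc1OC)C(CC(=O)N1CCCCC1)CC2` gives 40% in this assay, and the step of a number 13.3 percentage points higher from compound 2 to compound 3 (beyond the scatter) is the only one of the three that lies beyond the scatter. The same cyclic amide reached from the methylamino compound moves less: a number 6.7 percentage points higher from compound 1 to compound 3 (within the scatter).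

Compound 4 `COc1cc2c(cc1OC)C(CC(=O)N1CCOCC1)CC2` carries morpholin-4-yl in place of propylamino on a carbonyl carbon. Among the measured compounds shown here, the change again replaces an open-chain amine with a six-membered ring on the carbonyl carbon, so the steps that bear on it are a number 13.3 percentage points higher from compound 2 to compound 3 (beyond the scatter) and a number 6.7 percentage points higher from compound 1 to compound 3 (within the scatter). One of these was beyond the scatter, the other not, and the entering ring here holds one more hetero atom than piperidin-1-yl. For compound 4 a modest rise is expected, a number 9.3 percentage points higher from compound 2 to compound 4 (within the scatter). Compound 4 is therefore estimated at 36%, with a range from 22% to 50% in this assay.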

Compound 4, a percentage reported as inhibition, in the whole organism at one dose (the size of the read-out at that dose, not a potency): 23.3%
For compound 4 the middle estimate is 12.7 percentage points above the measured one, and the stated range covers the measured number.
By their numbers in this assay, from the lowest: compounds 4, 2, 1 and 3 (each within the scatter of the next, the first and the last beyond it).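

The rise seen with piperidin-1-yl does not carry over to every six-membered ring on this carbonyl carbon: replacing propylamino with morpholin-4-yl gives a number 3.4 percentage points lower from compound 2 to compound 4 (within the scatter). The direct exchange of the two rings is the clearest new comparison, with a number 16.7 percentage points lower from compound 3 to compound 4 (beyond the scatter) in this assay, so at this position the two rings are not interchangeable. Against the methylamino amide, morpholin-4-yl gives a number 10 percentage points lower from compound 1 to compound 4 (within the scatter), so it cannot be separated from either open-chain amide, while compound 3 stands clear of compound 2 and compound 4 but not of compound 1.

Nothing available here bears on what lies behind the gap between the two rings. Open, going by these compounds, is whether a pyrrolidin-1-yl or 4-methylpiperazin-1-yl group on the carbonyl carbon would fall with compound 3 or with compound 4.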